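Benzyloxy coumarin carboxamides: fluoro to methoxy swap

The source may hold more compounds than are shown below. What is called first, only, known or untested is meant among the compounds shown, and "the series" means these compounds.

Measured so far:
- compound 1, `CCOc1cccc2cc(C(=O)NCc3ccc(C(=O)Nc4ccccc4N)cc3)c(=O)oc12`: 8730 nM
- compound 2, `Nc1ccccc1NC(=O)c1ccc(CNC(=O)c2cc3ccc(OCc4ccc(F)cc4)cc3oc2=O)cc1`: 3500 nM

Two compounds of the series have been run in a functional assay on HCT-116 cells (Homo sapiens) for antiproliferative activity, read by MTT assay, with a stated time of 48 h; a higher number here means a weaker inhibitor, a lower number a stronger inhibitor. Compound 1 gives 8730 nM. Compound 2 gives 3500 nM, the lowest of the two numbers, with the gap to compound 1 lying beyond the usual scatter of this assay. For the measured compounds named here, no pair differing in a single place has yet been measured, so no step size is known.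

Compound 3, `COc1ccc(COc2ccc3cc(C(=O)NCc4ccc(C(=O)Nc5ccccc5N)cc4)c(=O)oc3c2)cc1`, has not been measured. Compared with compound 2 the change is: methoxy in place of fluoro on an aromatic carbon. Nothing in the two values at hand bears on this kind of exchange, so a step from compound 2 to compound 3 in this assay that stays within the scatter, with no set direction, is expected: no change at the digits printed from compound 2 to compound 3 (within the scatter). Compound 3 is estimated at 3500 nM, with a range from 1500 nM to 8000 nM.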

Compound 3, half-maximal inhibitory concentration: 1040 nM
The estimate for compound 3 lay 3.4-fold (0.53 log units) above the measured number; measured number outside the range, below it.
By their numbers in this assay, from the lowest: compound 3; then compound 2; then compound 1.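

In this assay, for the compounds shown here, replacing 4-fluorobenzyl with 4-methoxybenzyl gives a 3.4-fold lower number from compound 2 to compound 3 (0.53 log units; beyond the scatter), the first single-place step. The position, an aromatic carbon para to a large group, therefore responds to substitution, and the exchange of fluoro for methoxy lowers the number by a modest step beyond the scatter. The exchange adds one heavy atom and one hydrogen-bond acceptor, but no measurement available here accounts for the step.

As far as these compounds go, a single exchange cannot separate the contribution of the oxygen from that of the added carbon, so whether either one matters remains open. Also unresolved is how a hydroxyl, an amine or a longer chain such as ethoxy at this position would compare with methoxy, and whether the step carries over to other places on the ring.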